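Trifluoromethyl Added to the Anilide Ring of Compound 2

The compounds below may be only part of what the source reports. "The series", "measured", "known", "first", "only" and "open" are said of these compounds alone.

Measured compounds:
compound 1, `N=C(Nc1cccc(C(F)(F)F)c1)c1cc2c(-c3ccccc3)n[nH]c2cn1`: 19900 nM
compound 2, `Cn1nc(-c2ccccc2)c2cc(C(=N)Nc3ccccc3)ncc21`: 17300 nM

Of the compounds shown here, two sharing one core have been tested in a functional assay on PC-3 cells (Homo sapiens) for cytotoxicity, read by MTT assay, with a stated time of 72 h; on this read-out higher numbers stand for weaker inhibition and lower numbers for stronger inhibition. Compound 1 gives 19900 nM in this assay, and compound 2 gives 17300 nM. The two numbers lie within the usual scatter of each other, so compound 2 cannot be told apart from compound 1 on this read-out; both sit in the weak range.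

Compound 3 is `Cn1nc(-c2ccccc2)c2cc(C(=N)Nc3cccc(C(F)(F)F)c3)ncc21`, not yet measured. It differs from compound 2 by trifluoromethyl in place of hydrogen on an aromatic carbon. For the measured compounds named here, compound 1 carries the same trifluoromethyl on its anilide ring while differing from compound 2 elsewhere as well, so no single-change step is available to gauge the effect of this substituent on its own. Given that compound 1 and compound 2 read the same within scatter, the step in this assay is expected to be small, with no clear direction, and likely to stay inside the scatter.

The estimate for the step from compound 2 to compound 3 is a 1.0-fold higher number from compound 2 to compound 3 (0.02 log units; within the scatter). For compound 3 the expected value in this assay is 18000 nM, with a range from 8000 nM to 40000 nM.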

Compound 3, half-maximal inhibitory concentration: 20900 nM
Beside the measured number, compound 3's estimate is 1.2-fold (0.06 log units) below it; low and high end bracket the measured number.
By their numbers in this assay, from the lowest: compounds 2, 1 and 3 (each within the scatter of the next).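

In this assay, trifluoromethyl in place of hydrogen on an aromatic carbon, meta to a large group, can now be read as a single change, and it gives a 1.2-fold higher number from compound 2 to compound 3 (0.08 log units; within the scatter), so this substitution on the six-membered aromatic ring of carbon only does not separate the two compounds on this read-out. For the compounds shown here, the methyl on the aromatic nitrogen can also be read on its own for the first time, with a 1.1-fold higher number from compound 1 to compound 3 (0.02 log units; within the scatter), so this second change likewise leaves its pair indistinguishable, and all three compounds lie within the scatter of one another. No measurement shown here offers an explanation for either result.

As far as these compounds go, what remains open is whether a different group on the same aromatic carbon, such as an amine or a carboxylic acid, would give a step beyond the scatter. From the compounds shown here alone, it is equally open whether a longer chain in place of the methyl on the aromatic nitrogen would separate from these compounds in this assay, since the two steps cover only trifluoromethyl and methyl.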